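Carbamoyl in place of phenyl on the piperidine ring

The source may report more compounds than this note shows. Statements on the series, on what has been measured and on what is new or still open speak of the compounds shown alone.

Measured compounds:
compound 1 `CCOc1cc(N)c(Cl)cc1C(=O)CCCCN1CCCCC1`: in a functional assay for antagonist activity at 5-hydroxytryptamine receptor 4 (Rattus norvegicus) (on this read-out lower numbers stand for lower potency and higher numbers for higher potency (the scale is a negative logarithm)), compound 1 reaches only a limit, < 7.
compound 2 `COc1cc(COc2cc(N)c(Cl)cc2C(=O)CCCCN2CCC(C)CC2)cc(OC)c1`: compound 2 gives 8.3.
compound 3 `COc1cc(COc2cc(N)c(Cl)cc2C(=O)CCCCN2CCC(c3ccccc3)CC2)cc(OC)c1`: compound 3 gives 7.7.

Among the two numbers, compound 3 stands lowest, with compound 2 the nearer value, the change a number 0.60 log units lower from compound 2 to compound 3 (beyond the scatter) lying beyond the scatter. The remaining value is a limit, (the limit of < 7 in this assay, at which 1 of the 3 values shown sits), and gives no number to place compound 3 against.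

Compound 4 `COc1cc(COc2cc(N)c(Cl)cc2C(=O)CCCCN2CCC(C(N)=O)CC2)cc(OC)c1` differs from compound 3 in one place: carbamoyl in place of phenyl on a saturated ring carbon. For the measured compounds named here, the only measured step at this ring carbon is a number 0.60 log units lower from compound 2 to compound 3 (beyond the scatter), a modest loss on going from methyl to phenyl. Going by the values given here, no measured compound carries a carbamoyl there, so the direction for compound 4 cannot be read from a matching step. Compound 4 is therefore expected to stay near compound 3, with a step of a number 0.20 log units lower from compound 3 to compound 4 (within the scatter) inside the scatter. The estimate for compound 4 in this assay is 7.5, with a range from 6.8 to 8.3.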

Compound 4, negative logarithm of the antagonist equilibrium constant: 8.4
Compound 4: the middle estimate sits 0.90 log units below what was measured; the measured number lies above the stated range.
By their numbers in this assay, from the lowest: compound 3; then compounds 2 and 4 (each within the scatter of the next). At a limit, below all of these: compound 1.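

Carbamoyl in place of phenyl on this saturated ring carbon gives a number 0.70 log units higher from compound 3 to compound 4 (beyond the scatter) in this assay, so the earlier loss from methyl to phenyl does not extend to every replacement of methyl at this position. Carbamoyl in place of methyl gives a number 0.10 log units higher from compound 2 to compound 4 (within the scatter), which leaves these two groups indistinguishable on this read-out. Of the three groups compared at this ring carbon, phenyl alone stands apart, with steps beyond the scatter to both methyl and carbamoyl.

From the compounds shown here alone, whether an amine, a carboxylic acid or a longer chain at this ring carbon would stay level with methyl and carbamoyl remains open. So does whether a saturated cyclohexyl ring would follow phenyl. The evidence available offers no measurement that explains the difference between these groups.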